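Linker variation on the shared core: sulfur to nitrogen

The source may hold more compounds than are shown below. What is called first, only, known or untested is meant among the compounds shown, and "the series" means these compounds.

Measured so far in an assay on isolated protein for inhibition of aldehyde dehydrogenase 1A1 (Homo sapiens); on this read-out higher numbers stand for weaker inhibition and lower numbers for stronger inhibition:
- compound 1 `Cn1ncc2c(=O)n(-c3ccccc3)c(CCc3cccc(F)c3)nc21` gives 1000 nM
- compound 2 `Cn1ncc2c(=O)n(-c3ccccc3)c(CSc3cccc(F)c3)nc21` gives 720 nM

Compound 2 holds the lowest of the two numbers in this assay; its nearest neighbour is compound 1, and the step of a 1.4-fold lower number from compound 1 to compound 2 (0.14 log units; within the scatter) is within the scatter, so the two are treated as equal.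

Compound 3 `Cn1ncc2c(=O)n(-c3ccccc3)c(CNc3cccc(F)c3)nc21` is not yet measured. It differs from compound 2 as follows: (3-fluorophenyl)amino in place of (3-fluorophenyl)sulfanyl on a saturated chain carbon bound to an aromatic carbon.

Within the data shown here, only one measured step bears on this change, and only loosely: a 1.4-fold lower number from compound 1 to compound 2 (0.14 log units; within the scatter) exchanged one linker for another at the same saturated chain carbon and produced no movement beyond the scatter. Among the measured compounds shown here, no measured pair shows the (3-fluorophenyl)amino linker itself, so nothing in the data points to a direction. The working expectation is therefore a step of a 1.0-fold lower number from compound 2 to compound 3 (0.01 log units; within the scatter) of no more than the scatter in this assay.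

On that basis compound 3 is estimated at 700 nM in this assay, with a range from 250 nM to 2000 nM.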

Compound 3, half-maximal inhibitory concentration: 570 nM
The estimate for compound 3 lay 1.2-fold (0.09 log units) above the measured number; the range from low to high includes it.
By their numbers in this assay, from the lowest: compounds 3, 2 and 1 (each within the scatter of the next).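

In this assay, the (3-fluorophenyl)amino group adds a third linker at this saturated chain carbon, with a 1.3-fold lower number from compound 2 to compound 3 (0.10 log units; within the scatter) and a 1.8-fold lower number from compound 1 to compound 3 (0.24 log units; within the scatter), so compounds 1, 2 and 3 all stand within the scatter of one another. The exchange of (3-fluorophenyl)sulfanyl for (3-fluorophenyl)amino also goes from 0 to 1 hydrogen-bond donor at the same count of 8 heavy atoms, and this difference in the group brings no step beyond the scatter in this series. No supporting data accompany these three compounds to account for this flat result, and none bear on how the linkers compare beyond these numbers.

Still open, going by these compounds, is whether the flat picture extends to other linkers at this carbon, such as a (3-fluorophenyl)oxy group, a methylated amine, an amide or a longer chain. Also open, on these data alone, is whether a step beyond the scatter appears on the amino linker when a pyridine ring, a carboxylic acid or a morpholine replaces the 3-fluorophenyl ring.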